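The compounds below may be only part of what the source reports. "The series", "measured", "known", "first", "only" and "open" are said of these compounds alone.

- Compound 1 `COC(=O)CN1CCN(c2c(F)cc3c(=O)c(C(=O)O)cn(C4CC4)c3c2OC)CC1C`: 500 ug/mL
- Compound 2 `CO/N=C(\C)CCN1CCN(c2c(F)cc3c(=O)c(C(=O)O)cn(C4CC4)c3c2OC)CC1C`: 157 ug/mL

In an ADME assay on Vero cells (Chlorocebus sabaeus) for cytotoxicity, read by MTT assay, with a stated time of 72 h (on this read-out higher numbers stand for lower toxicity in this test and lower numbers for higher toxicity in this test), compound 2 stands at 157 ug/mL, the lower of the two numbers. Compound 3 `CCO/N=C(\C)CCN1CCN(c2c(F)cc3c(=O)c(C(=O)O)cn(C4CC4)c3c2OC)CC1C` differs from it by methyl in place of hydrogen on a saturated chain carbon bound to an oxygen on an unsaturated carbon, which turns methoxy to ethoxy. For the measured compounds named here, only one measured step bears on this, and only loosely: a 3.2-fold lower number from compound 1 to compound 2 (0.50 log units; beyond the scatter). That modest step replaced a larger group at another place, on a saturated chain carbon bound to an amine nitrogen in a ring. Going by the values given here, no measured step tests methoxy to ethoxy itself. No change beyond the scatter is therefore expected, and the estimated step is a 1.1-fold lower number from compound 2 to compound 3 (0.05 log units; within the scatter). Compound 3 is estimated at 140 ug/mL, with an expected range of 70 ug/mL to 280 ug/mL.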

Compound 3, half-maximal cytotoxic concentration: 88.4 ug/mL
Compound 3: the middle estimate sits 1.6-fold (0.20 log units) above what was measured; the range from low to high includes it.
By their numbers in this assay, from the lowest: compounds 3 and 2 (each within the scatter of the next); then compound 1.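

In this assay, the change from methoxy to ethoxy on a saturated chain carbon bound to an oxygen on an unsaturated carbon gives a 1.8-fold lower number from compound 2 to compound 3 (0.25 log units; within the scatter) and so stays within the scatter at this position. The larger replacement on a saturated chain carbon bound to an amine nitrogen in a ring, read as a 5.7-fold lower number from compound 1 to compound 3 (0.75 log units; beyond the scatter) in the same assay, stays beyond the scatter with ethoxy in place. No measurement offered here bears on the cause of either step. The compounds shown leave open whether a longer chain such as propoxy, or a hydroxy group, would move the number beyond the scatter at this position.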